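Phenyl substituent swaps in a glucagon receptor antagonist series

A few compounds are considered here, and "the series" means these few. Any claim that something is new, unique, unknown or untested is made for them only; others in the source may bear on it.

Measured so far:
compound 1 `CCCCCc1c(C(C)C)nc(C(C)C)c(CO)c1-c1ccc(C(F)(F)F)cc1`, 35%
compound 2 `CCCCCc1c(C(C)C)nc(C(C)C)c(CO)c1-c1ccc2c(c1)CCCC2`, 37%
compound 3 `CCCCCc1c(C(C)C)nc(C(C)C)c(CO)c1-c1cccc(Cl)c1`, 49%

All three share one core and differ only in the aryl group attached to it. In an assay on CHO cells for inhibition of Glucagon receptor (Homo sapiens), tested at 20 uM (a lower number here means less inhibition, a higher number more inhibition at the concentration tested (going by the name of the read-out)), compound 1 gives 35% and compound 2 gives 37%; these two numbers lie within the scatter of each other and cannot be ordered. Compound 3 gives 49%, the highest of the three, and its gaps to compound 2 and to compound 1 both fall beyond the scatter, so compound 3 has the highest number in this assay of the measured set.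

Compound 4 `CCCCCc1c(C(C)C)nc(C(C)C)c(CO)c1-c1cccc(C)c1` is not yet measured. It differs from compound 3 in one place: methyl in place of chloro on an aromatic carbon. For the measured compounds named here, no step between measured compounds covers this particular exchange, so the expectation rests on the size of the swap alone. A small step is expected, downward if anything, with a fair chance that it stays within the scatter; the step from compound 3 to compound 4 is estimated at a number 7 percentage points lower from compound 3 to compound 4 (within the scatter). Compound 4 is therefore expected to give about 42% in this assay, with a range from 25% to 58%.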

Compound 4, a percentage reported as inhibition, at one concentration (the size of the read-out at that concentration, not a potency): 46%
Beside the measured number, compound 4's estimate is 4 percentage points below it; the measured number falls inside the stated range.
By their numbers in this assay, from the lowest: compounds 1, 2, 4 and 3 (each within the scatter of the next, the first and the last beyond it).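

The exchange of 3-chlorophenyl for 3-methylphenyl gives the series its first step between two measured compounds, and in this assay it reads a number 3 percentage points lower from compound 3 to compound 4 (within the scatter). At this position on the aryl ring, chloro and methyl therefore cannot be told apart in this read-out, and chlorine is not shown to be required there. Nothing available on either group bears on this result, so the step stands without an explanation.

Open at the same position are the unsubstituted phenyl, methoxy, an amine and a carboxylic acid, any of which could show whether the number responds to this site at all. Also open, going by these compounds, is what happens elsewhere on the shared core, for example with a carboxylic acid in place of the hydroxymethyl or a longer chain in place of pentyl.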